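Longer ether chain on the shared core: working notes

The source may hold more compounds than are shown below. What is called first, only, known or untested is meant among the compounds shown, and "the series" means these compounds.

In an ADME assay on RAW264.7 cells (Mus musculus) for cytotoxicity, read by MTT assay, with a stated time of 24 h, in the presence of a further agent that is not named here (a higher number here means a weaker inhibitor, a lower number a stronger inhibitor), compound 1 (`COc1ccc(C(O)C2OC(=O)c3c(OC)cc(OC)cc32)cc1`) gives > 40000 nM as a limit and not a number. Compound 2 (`CCOc1ccc(C(O)C2OC(=O)c3c(OC)cc(OC)cc32)cc1`) gives > 40000 nM as a limit too. Compound 3 (`COCCOc1ccc(C(O)C2OC(=O)c3c(OC)cc(OC)cc32)cc1`) gives > 40000 nM as a limit as well and so has no number of its own. That makes the limit of > 40000 nM in this assay, at which 3 of the 3 values shown sit, the whole picture so far.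

Compound 4 (`COCCCCOc1ccc(C(O)C2OC(=O)c3c(OC)cc(OC)cc32)cc1`) carries 2-methoxyethyl in place of methoxy on a saturated chain carbon, two bonds along the chain from an oxygen on an aromatic ring. The steps bearing on this chain are a step that the two limits leave unreadable from compound 1 to compound 2 together with a step that the two limits leave unreadable from compound 1 to compound 3 and a step that the two limits leave unreadable from compound 2 to compound 3 and none of them has a readable size. No size or direction can be carried over from them, so nothing beyond the scatter is expected in this assay for this change. The expected step is a number no higher from compound 3 to compound 4 (the limit leaves the size open) and it remains an estimate only. For compound 4 the estimated value is 40000 nM with an expected range from 20000 nM to 80000 nM and a report as a limit alone is the likeliest outcome.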

Compound 4, half-maximal inhibitory concentration: > 40000 nM
Compound 4 ended at the assay's limit (the forecaster's own chance of this, stated with the estimate: 85%); the middle value lies on the limit itself.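

In this assay no new step can be read between compound 4 and compound 1, compound 2 or compound 3, as each gives a limit and not a number. The compounds shown leave open whether these ether chains on the shared core differ at all: the limit of > 40000 nM in this assay, at which 4 of the 4 values shown sit.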